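This account rests on a few compounds, and the source may have more. Where it says the series, first, only, none or still open, it means among the compounds named here.

Compound 1 `O=C1C=CC2(C=C1)OCC(=O)N2S(=O)(=O)c1ccccc1` gives > 10000 nM in a functional assay on HeLa cells (Homo sapiens) for inhibition, read by sulforhodamine B assay, with a stated time of 74 h (a lower number here means a stronger inhibitor, a higher number a weaker inhibitor), and this is a limit of the assay, not a number. It stands at the limit of > 10000 nM in this assay, at which 1 of the 3 values shown sits, so any step away from compound 1 is known only as a bound.

Two relatives carry one extra group on the aromatic ring of compound 1. In this assay, compound 2 `N#Cc1cccc(S(=O)(=O)N2C(=O)COC23C=CC(=O)C=C3)c1` reads 180 nM, with cyano in place of hydrogen on an aromatic carbon. Compound 3 `O=C1C=CC2(C=C1)OCC(=O)N2S(=O)(=O)c1ccccc1OC(F)(F)F` reads 140 nM, with trifluoromethoxy in place of hydrogen on an aromatic carbon. These changes give an at least 55-fold lower number from compound 1 to compound 2 (1.74 log units; beyond the scatter) and an at least 71-fold lower number from compound 1 to compound 3 (1.85 log units; beyond the scatter), both large.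

Compound 4 `O=C1C=CC2(C=C1)OCC(=O)N2S(=O)(=O)c1cccs1` keeps the core of compound 1 but has thiophen-2-yl in place of phenyl on a sulfonyl sulfur. Neither measured step makes this exchange, and compound 4 carries neither added group, so they bear on it only indirectly. They show that a change to this aromatic part can move the number a long way, and the direction available from the limit of compound 1 is downward. A lower number is therefore expected in this assay, though a smaller move than in those two steps, and compound 4 may yet remain at the limit.

The expected step is an at least 5.0-fold lower number from compound 1 to compound 4 (0.69 log units; beyond the scatter). For compound 4 the estimated value is 2000 nM, with an expected range of 250 nM to 10000 nM.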

Compound 4, half-maximal inhibitory concentration: 3420 nM
Compound 4: the middle estimate sits 1.7-fold (0.23 log units) below what was measured; measured number inside the range.
By their numbers in this assay, from the lowest: compounds 3 and 2 (each within the scatter of the next); then compound 4. At a limit, above all of these: compound 1.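

In this assay, exchanging phenyl for thiophen-2-yl on a sulfonyl sulfur gives an at least 2.9-fold lower number from compound 1 to compound 4 (0.46 log units; beyond the scatter), and this is the only step shown in which the aromatic ring itself is replaced. Among the compounds shown here, compounds 2 and 3 had left the phenyl in place and carried an added group, whereas compound 4 carries neither cyano nor trifluoromethoxy and still reads as a number rather than a limit, so at this position an added group is not the only change that brings the reading off the limit. The size of the step remains a bound, and how far the exchange truly moves the number cannot be read: the limit of > 10000 nM in this assay, at which 1 of the 4 values shown sits.

The compounds shown do not tell whether the sulfur of thiophen-2-yl or the five-membered ring as such goes with the lower number, a question that furan-2-yl or a six-membered pyridinyl ring on the sulfonyl sulfur would bear on. They also leave open whether cyano or trifluoromethoxy on the thiophen-2-yl ring would lower the number further, and how an amine or a carboxylic acid on either aromatic ring would read.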